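The source may report more compounds than this note shows. Statements on the series, on what has been measured and on what is new or still open speak of the compounds shown alone.

Measured so far:
compound 1, `O=C1O[C@@H](CO)CN1c1ccc(-n2cc(-c3ccccn3)cn2)c(F)c1` — 56400 nM in a physicochemical assay for solubility, read by HPLC, with a stated time of 24 h; a higher number here means a more soluble compound, a lower number a less soluble compound
compound 2, `O=C1O[C@@H](Cn2ccnn2)CN1c1ccc(-n2cc(-c3ccccn3)cn2)c(F)c1` — 247000 nM in this assay

For the measured compounds named here, compound 2 stands highest of the two numbers in this assay; the only neighbour is compound 1, and the single measured step is a 4.4-fold higher number from compound 1 to compound 2 (0.64 log units; beyond the scatter), a modest rise beyond the scatter.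

The next compound is compound 3, `CNC(=O)[C@H]1CN(c2ccc(-n3cc(-c4ccccn4)cn3)c(F)c2)C(=O)O1`, not yet measured in this assay. It differs from compound 2 as follows: methylcarbamoyl in place of (1H-1,2,3-triazol-1-yl)methyl on a saturated ring carbon. Going by the values given here, no measured step covers this change. Among the compounds with values here, the one step in hand, a 4.4-fold higher number from compound 1 to compound 2 (0.64 log units; beyond the scatter), concerns a different exchange at the same carbon and so bears on it only loosely: it shows that a change at this position can move the number by a modest amount. Since the group that enters has fewer heavy atoms and carries a hydrogen-bond donor, as does the hydroxy of compound 1, the number for compound 3 is expected to fall back toward that of compound 1 rather than stay at the level of compound 2, with wide uncertainty.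

The estimated step is a 2.5-fold lower number from compound 2 to compound 3 (0.39 log units; beyond the scatter). Compound 3 is therefore estimated at 100000 nM, within 30000 nM to 350000 nM.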

Compound 3, solubility: 26200 nM
Compound 3: middle estimate off by 3.8-fold (0.58 log units), on the high side, outside the stated range (below it).
By their numbers in this assay, from the lowest: compound 3; then compound 1; then compound 2.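

At the saturated ring carbon next to the ring oxygen, exchanging (1H-1,2,3-triazol-1-yl)methyl for methylcarbamoyl gives a 9.4-fold lower number from compound 2 to compound 3 (0.97 log units; beyond the scatter) in this assay, so this position can also carry the number downward, and by more than the scatter. The step of a 2.2-fold lower number from compound 1 to compound 3 (0.33 log units; beyond the scatter) places methylcarbamoyl lowest of the three groups at this carbon, even though it carries a hydrogen-bond donor, as the hydroxy of compound 1 does, while the departing triazolyl group carries none; having a donor in the group therefore does not by itself fix the number at the level of compound 1. Nothing available accounts for this order, and no separate measurement bears on the cause of either step.

Three groups define the order at this one carbon, and they differ at once in heavy atoms, ring content and donors, so none of these features can be separated from the others. An unsubstituted carboxamide, a carboxylic acid, an amine or a longer chain ending in hydroxy at the same carbon would show how far the order extends and whether the methyl on the amide nitrogen matters.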